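The source may hold more compounds than are shown below. What is called first, only, known or untested is meant among the compounds shown, and "the series" means these compounds.

Three related amides have been tested in an assay on isolated protein for inhibition of Matrilysin (Homo sapiens); a higher number here means a weaker inhibitor, a lower number a stronger inhibitor. Compound 1 `O=C(NCc1ccc(-c2ccccc2)cc1)c1cccc(=O)n1O` gives 25000 nM in this assay. Compound 2 `O=C(NCc1ccc(-c2ccccc2)cc1)c1occc(=O)c1O` gives 25000 nM in this assay. The step of no change at the digits printed from compound 1 to compound 2 (within the scatter) is therefore flat. Compound 3 `Cn1ccc(=O)c(O)c1C(=O)NCc1ccc(-c2ccccc2)cc1` gives 25000 nM in this assay, a value that sits at the same figure as those of compound 1 and compound 2; nothing separates the three compounds on the numbers shown, and none of them can be called stronger or weaker than another.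

The next compound, compound 4 `Cc1cc(=O)c(O)c(C(=O)NCc2ccc(-c3ccccc3)cc2)n1C`, differs from compound 3 by methyl in place of hydrogen on an aromatic carbon, that is, a methyl in place of hydrogen on an aromatic carbon. Among the measured compounds shown here, no measured step in this set touches that position or that kind of change. For the measured compounds named here, the only measured step exchanged the whole ring group on the carbonyl carbon and produced no movement in this assay. The three measured values give no sign that this assay distinguishes any of the compounds, so there is no ground to expect movement beyond the scatter in this assay. The step expected from compound 3 to compound 4 is no change at the digits printed from compound 3 to compound 4 (within the scatter). For compound 4 the estimate in this assay is 25000 nM, with a range from 8000 nM to 60000 nM.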

Compound 4, half-maximal inhibitory concentration: 25000 nM
Compound 4: the middle estimate sits on the measured number at the digits printed; measured number inside the range.
By their numbers in this assay, from the lowest: compounds 1, 2, 3 and 4 (each within the scatter of the next).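

Methyl in place of hydrogen on an aromatic carbon, next to the ring nitrogen and para to a hydroxy group, gives no change at the digits printed from compound 3 to compound 4 (within the scatter) in this assay and so provides a reading at this position, whereas the only earlier step exchanged the whole ring group on the carbonyl carbon. The result shows that this single added carbon, unlike that broader exchange, is a small local change to one ring, yet compound 4 at 25000 nM in this assay still stands on the figure shared by compounds 1, 2 and 3, so the four compounds cannot be ranked. Nothing at hand offers an explanation for this flat step.

As far as these compounds go, whether an amine, a carboxylic acid or a longer chain at this same position would leave the number where it stands remains open, as a methyl tells nothing about those groups. Also open, from the compounds shown here alone, is whether any change to the shared core can move the value at all in this assay when all four compounds print the same figure.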